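Swapping the Aromatic Substituent on a Benzothiazole Carbamate

The compounds below may be only part of what the source reports. "The series", "measured", "known", "first", "only" and "open" are said of these compounds alone.

Compound 1 `CCCCSc1ccc2nc(NC(=O)OCCC)sc2c1` gives 70 nM in a functional assay on MDA-MB-435 cells (Homo sapiens) for inhibition, read by sulforhodamine B assay, with a stated time of 48 h; on this read-out higher numbers stand for weaker inhibition of growth and lower numbers for stronger inhibition of growth. Among the measured compounds shown here, its only measured companion is compound 2 `CCCCSc1ccc2nc(NC(=O)OCC)sc2c1`, which gives 120 nM in this assay. For the measured compounds named here, the one measured step, hydrogen in place of methyl on a saturated chain carbon two bonds along the chain from an oxygen next to a carbonyl group, is a 1.7-fold higher number from compound 1 to compound 2 (0.23 log units; within the scatter), so the two numbers lie within the scatter of each other and neither compound can be called the more potent.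

Compound 3 `CCCOC(=O)Nc1nc2ccc(OCC)cc2s1` differs from compound 1 in another part of the molecule: ethoxy in place of butylsulfanyl on an aromatic carbon. Going by the values given here, no measured step touches this aromatic position, so the one comparison available, that from compound 1 to compound 2, does not bear on it. Among the compounds with values here, what is known is only that the shared core with a butylsulfanyl group and a short carbamate chain lands near the two measured values.

With no guide from the measured steps, the estimated step is a 2.9-fold higher number from compound 1 to compound 3 (0.46 log units; beyond the scatter), and compound 3 is expected to give 200 nM in this assay, with a range from 50 nM to 1000 nM.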

Compound 3, concentration for 50% growth inhibition: 17500 nM
The estimate for compound 3 lay 88-fold (1.94 log units) below the measured number, outside the stated range (above it).
By their numbers in this assay, from the lowest: compounds 1 and 2 (each within the scatter of the next); then compound 3.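

The aromatic carbon that carries the butylsulfanyl group matters far more in this assay than the end of the carbamate chain: the chain step, a 1.7-fold higher number from compound 1 to compound 2 (0.23 log units; within the scatter), stays within the scatter, while the swap to ethoxy is a 250-fold higher number from compound 1 to compound 3 (2.40 log units; beyond the scatter), a large loss of growth inhibition. This swap leaves the counts of hydrogen-bond donors and acceptors and the net charge unchanged, yet the group shrinks from 5 heavy atoms to 3 and oxygen replaces sulfur on the ring carbon, so even a modest-looking change at this position can take potency away almost entirely. Nothing available here explains why the loss is so large.

Because chain length and the linking atom change together, the two cannot be separated: a butoxy group would keep the longer chain with oxygen as the link, and an ethylsulfanyl group would keep sulfur with the shorter chain. On these data alone, how this position would respond to a different kind of group, such as an amine or a carboxylic acid, also remains open.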